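Alkyne substituent change on the shared core

The source may report more compounds than this note shows. Statements on the series, on what has been measured and on what is new or still open speak of the compounds shown alone.

Measured compounds:
compound 1 `CCCCCCC#Cc1cn(C/C=C/CN2C(=O)c3ccccc3C2=O)c(=O)[nH]c1=O` — 24000 nM
compound 2 `CCCCCc1ccc(C#Cc2cn(C/C=C\CN3C(=O)c4ccccc4C3=O)c(=O)[nH]c2=O)cc1` — > 100000 nM
compound 3 `O=C1c2ccccc2C(=O)N1C/C=C/Cn1cc(C#CCCc2ccccc2)c(=O)[nH]c1=O` — 13000 nM

In a functional assay on MCF7 cells (Homo sapiens) for antiproliferative activity, read by MTT assay, with a stated time of 3 days (a higher number here means a weaker inhibitor, a lower number a stronger inhibitor), compound 3 gives 13000 nM, the lowest of the two plain numbers, with compound 1 nearest at 24000 nM. The step of a 1.8-fold lower number from compound 1 to compound 3 (0.27 log units; within the scatter) lies within the scatter, so compounds 1 and 3 cannot be told apart. For compound 2 the assay reports only a limit, > 100000 nM (the limit of > 100000 nM in this assay, at which 1 of the 3 values shown sits).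

Compound 4 `CCCCCc1ccc(C#Cc2cn(C/C=C/CN3C(=O)c4ccccc4C3=O)c(=O)[nH]c2=O)cc1` differs from compound 3 in one place: 4-pentylphenyl in place of phenethyl on a triple-bonded carbon. Going by the values given here, no measured step covers this change, since the step from compound 1 to compound 3 alters a saturated chain carbon, not the atom carrying the aromatic ring. Compound 2 carries the same 4-pentylphenyl on a triple-bonded carbon and reached only the limit, but it also differs from compound 4 elsewhere, so it gives only a hint of direction.

Taken together, a weaker result than compound 3 is expected, with a real chance of another limit. The step of a 3.8-fold higher number from compound 3 to compound 4 (0.59 log units; beyond the scatter) is therefore estimated as an increase. Compound 4 is expected at 50000 nM, within 15000 nM to 160000 nM.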

Compound 4, half-maximal inhibitory concentration: 5600 nM
Compound 4: middle estimate off by 8.9-fold (0.95 log units), on the high side, and the stated range ends above it.
By their numbers in this assay, from the lowest: compound 4; then compounds 3 and 1 (each within the scatter of the next). At a limit, above all of these: compound 2.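

In this assay, the group on the triple-bonded carbon does matter: 4-pentylphenyl gives a real gain over phenethyl, a 2.3-fold lower number from compound 3 to compound 4 (0.37 log units; beyond the scatter), and over hexyl, a 4.3-fold lower number from compound 1 to compound 4 (0.63 log units; beyond the scatter), both modest but beyond the scatter, whereas the earlier comparison of compounds 1 and 3 showed no difference. Compound 2 carries the same 4-pentylphenyl but gives no plain number, only a limit: the limit of > 100000 nM in this assay, at which 1 of the 4 values shown sits. Its poor result therefore says nothing against this group, as the large step, an at least 17-fold lower number from compound 2 to compound 4 (1.25 log units; beyond the scatter), goes with the double bond, drawn Z in compound 2 and E in compound 4: the fact that compounds 2 and 4 differ only in the configuration as drawn.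

The compounds shown do not separate the aromatic ring of 4-pentylphenyl from its pentyl chain, so it remains open whether a bare phenyl or a 4-aminophenyl on the triple-bonded carbon would keep the gain. Going by these compounds alone, it also remains open whether the Z double bond would cost as much with hexyl or phenethyl on the triple-bonded carbon, as the only Z compound here carries 4-pentylphenyl.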